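Replacing the anilino group on the shared core

The source may report more compounds than this note shows. Statements on the series, on what has been measured and on what is new or still open speak of the compounds shown alone.

Measured so far:
- compound 1 `Cc1ccc(Nc2ncc3c(n2)N(C)C(=O)N(c2cc(NC(=O)c4cccc(C(F)(F)F)c4)ccc2C)C3)cc1`: 18 nM
- compound 2 `Cc1ccc(NC(=O)c2cccc(C(F)(F)F)c2)cc1N1Cc2cnc(OC3CCN(C(=O)OC(C)(C)C)CC3)nc2N(C)C1=O`: 29 nM
- compound 3 `Cc1ccc(Nc2ncc3c(n2)N(C)C(=O)N(c2cc(NC(=O)c4cccc(-c5ccccc5)c4)ccc2C)C3)cc1N`: 23 nM

The three compounds share a core and differ mainly in the group sitting between the two ring nitrogen atoms of the bicyclic system and in the amide substituent. In a functional assay on K562 cells (Homo sapiens) for antiproliferative activity, read by CellTiter-Glo and CCK-8 assay, with a stated time of 72 h (a higher number here means a weaker inhibitor of growth, a lower number a stronger inhibitor of growth), compound 1 gives 18 nM, the lowest of the three numbers, but its gaps to compound 3 and to compound 2 both lie within the scatter, so no order among the three can be read from these data. Compound 2, which carries an oxygen-linked saturated ring with a carbamate at the same place, shows that an anilino group is not required to keep the number low.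

Compound 4 `Cc1ccc(NC(=O)c2cccc(C(F)(F)F)c2)cc1N1Cc2cnc(O[C@H]3CCNC3)nc2N(C)C1=O` is not yet measured. It differs from compound 1 as follows: (pyrrolidin-3-yl)oxy in place of (4-methylphenyl)amino on an aromatic carbon. Among the measured compounds shown here, no measured pair isolates this exact change, so its size is unknown. Given that compound 2 gives 29 nM with a related oxygen-linked ring, a step beyond the scatter in either direction is not strongly indicated, though a small move to a higher number seems the more likely outcome.

For compound 4 the expected value in this assay is 40 nM, with a range from 12 nM to 150 nM. The estimated step from compound 1 to compound 4 is a 2.2-fold higher number from compound 1 to compound 4 (0.35 log units; beyond the scatter).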

Compound 4, concentration for 50% growth inhibition: 450 nM
Compound 4: middle estimate off by 11-fold (1.05 log units), on the low side; measured number above the stated range.
By their numbers in this assay, from the lowest: compounds 1, 3 and 2 (each within the scatter of the next); then compound 4.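

Putting (pyrrolidin-3-yl)oxy in place of (4-methylphenyl)amino, on the aromatic carbon between two ring nitrogen atoms, gives in this assay a 25-fold higher number from compound 1 to compound 4 (1.40 log units; beyond the scatter) and so shows that this position does not accept every replacement of the anilino group. An oxygen link alone does not keep the number low: compound 2, with its oxygen-linked saturated ring and carbamate, gives 29 nM and compound 4 gives 450 nM, so what the oxygen carries matters here. Nothing measured on these compounds gives a reason for this step.

Compound 4 differs from compound 2 in ring size, in the defined stereocentre and in the absence of the carbamate, and the values shown do not separate these features. On these data alone, it remains open whether a (piperidin-4-yl)oxy group without the carbamate, a (pyrrolidin-3-yl)oxy group with a carbamate on its ring nitrogen, or the opposite stereoisomer of compound 4 would bring the number back towards those of the other compounds, and whether a small methoxy group at this place would do the same.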